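Compound 1 and its 2-methoxyphenyl counterpart, compound 4

The compounds below may be only part of what the source reports. "The series", "measured", "known", "first", "only" and "open" are said of these compounds alone.

In an ADME assay on HEK293 cells (Homo sapiens) for cytotoxicity, read by reporter gene assay and resazurin assay, with a stated time of 48 h (a higher number here means that more compound is tolerated, a lower number that less compound is tolerated), compound 1 `O=C(Nc1ccc(Sc2nc3ccccc3s2)c(Cl)c1)c1cccc(Br)c1O` gives 64000 nM, and compound 3 `O=C(Nc1ccc(Sc2nc3ccccc3s2)cc1)c1cccc(Br)c1O` gives 71000 nM. These two numbers lie within the scatter of each other: the step is a 1.1-fold higher number from compound 1 to compound 3 (0.05 log units; within the scatter), with hydrogen in place of chloro on an aromatic carbon. In this assay compound 2 `COc1ccccc1C(=O)Nc1cccc(Cl)c1` gives > 100000 nM, which is a limit and not a number.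

Compound 4 `COc1ccccc1C(=O)Nc1ccc(Sc2nc3ccccc3s2)c(Cl)c1` is compound 1 with 2-methoxyphenyl in place of 3-bromo-2-hydroxyphenyl on a carbonyl carbon. Going by the values given here, no measured step changes this group, and the one measured step, a 1.1-fold higher number from compound 1 to compound 3 (0.05 log units; within the scatter), concerns another place, so it offers only a sign that the core of compound 1 tolerates some change. Compound 2 also carries 2-methoxyphenyl on a carbonyl carbon, but it lacks the core of compound 1, and its value is a limit, so it gives only a weak hint toward more compound being tolerated.

The expected change in this assay is small, and the estimate is a 1.3-fold higher number from compound 1 to compound 4 (0.12 log units; within the scatter). For compound 4 the estimated value is 85000 nM, with an expected range of 45000 nM to 130000 nM.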

Compound 4, half-maximal cytotoxic concentration: > 100000 nM
Compound 4: a limit, no number (the forecaster's own chance of this, stated with the estimate: 40%); at least 1.1-fold (0.07 log units) between middle value and limit.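

Going by these compounds alone, the step at this place is the first one measured on the group bound to the carbonyl carbon, and in this assay it reads an at least 1.5-fold higher number from compound 1 to compound 4 (0.19 log units; that floor lies within the scatter). With the core of compound 1 kept, 2-methoxyphenyl, which has no hydrogen-bond donor, can thus replace 3-bromo-2-hydroxyphenyl without less compound being tolerated, though the floor of this step lies within the scatter. The full size of the step cannot be told, because the reading for compound 4 is a limit and not a number: the limit of > 100000 nM in this assay, at which 2 of the 4 values shown sit.

The compounds shown do not separate the bromo part of the group that leaves from its hydroxy part, nor the methoxy part of the group that enters from its ring. Going by these compounds, it also remains open how an amine or a carboxylic acid on that ring would read in this assay.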